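Aryl triazole series: para-substituent removal, cytotoxicity readout

A few compounds are considered here, and "the series" means these few. Any claim that something is new, unique, unknown or untested is made for them only; others in the source may bear on it.

Measured compounds:
- compound 1, `COc1nc2ccc(Br)cc2cc1C(c1ccccc1)n1cc(-c2ccc(Br)cc2)nn1`: 6.28%
- compound 2, `CCCCCCCc1cn(C(c2ccccc2)c2cc3cc(Br)ccc3nc2OC)nn1`: 0.17%
- compound 3, `COc1nc2ccc(Br)cc2cc1C(c1ccccc1)n1cc(-c2ccc(F)cc2)nn1`: 4.04%

All three were read in an ADME assay on HEK293 cells (Homo sapiens) for cytotoxicity, read by sulforhodamine B assay, with a stated time of 48 h, tested at 10 uM; a higher number here means more inhibition at the concentration tested (going by the name of the read-out), a lower number less inhibition. Compound 3 stands second highest of the three numbers, with compound 1 nearest (a number 2.2 percentage points lower from compound 1 to compound 3 (within the scatter)) and compound 2 furthest (a number 3.9 percentage points higher from compound 2 to compound 3 (within the scatter)); every step between the measured compounds lies within the scatter, including a number 6.1 percentage points lower from compound 1 to compound 2 (within the scatter).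

Compound 4, `COc1nc2ccc(Br)cc2cc1C(c1ccccc1)n1cc(-c2ccccc2)nn1`, is not yet measured. It differs from compound 3 by hydrogen in place of fluoro on an aromatic carbon. The step bearing most directly on it is the exchange of bromo for fluoro at the same position, a number 2.2 percentage points lower from compound 1 to compound 3 (within the scatter), which stayed within the scatter; so did the larger exchanges of the whole group. No step beyond the scatter is therefore expected for a number 0 percentage points lower from compound 3 to compound 4 (within the scatter). Compound 4 is estimated at 4%, with a range from -4% to 12%.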

Compound 4, a percentage reported as inhibition, at one concentration (the size of the read-out at that concentration, not a potency): 8.25%
Beside the measured number, compound 4's estimate is 4.3 percentage points below it; measured number inside the range.
By their numbers in this assay, from the lowest: compounds 2, 3, 1 and 4 (each within the scatter of the next).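

With hydrogen at this position, para to a large group, this assay still does not separate the substituents: the fluoro exchange gives (a number 4.2 percentage points higher from compound 3 to compound 4 (within the scatter)) and the bromo exchange gives (a number 2 percentage points higher from compound 1 to compound 4 (within the scatter)). Compound 4 therefore shows that the unsubstituted phenyl reads alongside both halogens, and the exchange for heptyl also stays unresolved (a number 8.1 percentage points higher from compound 2 to compound 4 (within the scatter)). Nothing available explains these small steps.

Going by these compounds, whether an amine or a carboxylic acid at this position would give a step beyond the scatter remains open. So does the effect of replacing the bromo on the shared core.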